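This account rests on a few compounds, and the source may have more. Where it says the series, first, only, none or still open, it means among the compounds named here.

Compound 1 `CCOC(=O)c1cnc(C)nc1NN1C(=O)C=C(C)C1=O` is the starting point of this comparison, and it stands at the weak end of the three compounds measured in a functional assay on Jurkat cells for inhibition of nuclear factor NF-kappa-B complex (Homo sapiens); on this read-out lower numbers stand for stronger inhibition and higher numbers for weaker inhibition: compound 1 gives 16000 nM. The two other measured compounds share its core and differ only in the group that sits on the aromatic carbon between two ring nitrogen atoms. Compound 2 `CCOC(=O)c1cnc(-c2ccncc2)nc1NN1C(=O)C=C(C)C1=O` carries a pyridin-4-yl group there and gives 6000 nM, while compound 3 `CCOC(=O)c1cnc(-c2ccc(Cl)s2)nc1NN1C(=O)C=C(C)C1=O` carries a 5-chlorothiophen-2-yl group and gives 300 nM.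

Compound 4 `CCOC(=O)c1cnc(-c2cc3ccccc3s2)nc1NN1C(=O)C=C(C)C1=O` changes the same position: 1-benzothiophen-2-yl in place of methyl on an aromatic carbon. The entering group is again a sulfur-containing five-membered aromatic ring, here fused to a six-membered aromatic ring of carbon only.

Among the measured compounds shown here, two measured steps bear on this. Swapping methyl for pyridin-4-yl gave a 2.7-fold lower number from compound 1 to compound 2 (0.43 log units; beyond the scatter), a modest gain. Swapping methyl for 5-chlorothiophen-2-yl gave a 53-fold lower number from compound 1 to compound 3 (1.73 log units; beyond the scatter), a large gain, and the direct comparison of the two aromatic groups gave a 20-fold lower number from compound 2 to compound 3 (1.30 log units; beyond the scatter). Because the step of a 53-fold lower number from compound 1 to compound 3 (1.73 log units; beyond the scatter) came from a closely related sulfur ring, a large improvement is expected for compound 4 as well, in the direction of stronger inhibition, roughly a 40-fold lower number from compound 1 to compound 4 (1.60 log units; beyond the scatter). Compound 4 is therefore estimated at 400 nM, with a likely range from 100 nM to 2000 nM.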

Compound 4, half-maximal inhibitory concentration: 4000 nM
Beside the measured number, compound 4's estimate is 10-fold (1.00 log units) below it, outside the stated range (above it).
By their numbers in this assay, from the lowest: compound 3; then compounds 4 and 2 (each within the scatter of the next); then compound 1.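

In this assay, a sulfur-containing five-membered aromatic ring at this position does not by itself bring the large gain seen with compound 3: the fused 1-benzothiophen-2-yl group gives only a modest improvement over methyl (a 4.0-fold lower number from compound 1 to compound 4 (0.60 log units; beyond the scatter)), and putting it in place of 5-chlorothiophen-2-yl costs a large amount (a 13-fold higher number from compound 3 to compound 4 (1.12 log units; beyond the scatter)). Pyridin-4-yl, which has no sulfur, and 1-benzothiophen-2-yl also fall within the usual scatter of each other (a 1.5-fold lower number from compound 2 to compound 4 (0.18 log units; within the scatter)), so among these compounds sulfur does not separate the groups, with compound 3 as the one exception. Among the compounds shown here, all three aromatic groups improve on methyl, but the size of the improvement depends strongly on which group is used, so this position is more selective than the earlier compounds could show.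

From the compounds shown here alone, it remains open whether the gain of compound 3 rests on its chlorine atom or on the single thiophene ring, a question that a plain thiophen-2-yl group or a 5-bromothiophen-2-yl group would help to answer. Also open, going by these compounds, is how a phenyl group or an amine would behave here, and no measured evidence is available to explain why these groups differ.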